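Notes on a triazole-diol side chain replacement

This account rests on a few compounds, and the source may have more. Where it says the series, first, only, none or still open, it means among the compounds named here.

Compound 1 `CN1CCN(CCCCn2c3c(c4ccccc42)C(=O)c2c[n+]([O-])c4ccccc4c2C3=O)CC1` gives 90 nM in a functional assay on A549 cells (Homo sapiens) for cytotoxicity, read by MTT assay, with a stated time of 72 h (a lower number here means a stronger inhibitor, a higher number a weaker inhibitor), which places it at the low end of the three numbers, though within the scatter of both others. Compound 2 `O=C1c2c[n+]([O-])c3ccccc3c2C(=O)c2c1c1ccccc1n2CCCCN1CCCCC1` gives 150 nM and compound 3 `CN1CCN(CCCn2c3c(c4ccccc42)C(=O)c2c[n+]([O-])c4ccccc4c2C3=O)CC1` gives 140 nM. The measured steps are a 1.7-fold higher number from compound 1 to compound 2 (0.22 log units; within the scatter), a 1.6-fold higher number from compound 1 to compound 3 (0.19 log units; within the scatter) and a 1.1-fold lower number from compound 2 to compound 3 (0.03 log units; within the scatter); none reaches beyond the scatter, so swapping one six-membered non-aromatic ring for another, or shortening the chain, leaves this assay essentially unchanged. Compound 4 `O=C1c2c[n+]([O-])c3ccccc3c2C(=O)c2c1c1ccccc1n2Cc1cn(C[C@@H](O)CO)nn1` differs from compound 1 by 1-(2,3-dihydroxypropyl)-1H-1,2,3-triazol-4-yl in place of 3-(4-methylpiperazin-1-yl)propyl on a saturated chain carbon bound to an aromatic nitrogen. Among the compounds with values here, this change is of another kind: the group that leaves and the group that enters share no ring, and no measured pair tests such a swap, so the three steps show only that this position tolerates variation among related chains. Compound 4 is therefore expected to come out weaker, estimated at 300 nM with a range from 80 nM to 1500 nM. The expected step is a 3.3-fold higher number from compound 1 to compound 4 (0.52 log units; beyond the scatter).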

Compound 4, half-maximal inhibitory concentration: 390 nM
Estimate against measurement, compound 4: 1.3-fold (0.11 log units) below; the measured number falls inside the stated range.
By their numbers in this assay, from the lowest: compounds 1, 3 and 2 (each within the scatter of the next); then compound 4.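

In this assay, within the data shown here, 1-(2,3-dihydroxypropyl)-1H-1,2,3-triazol-4-yl is the first replacement at this position to give steps beyond the scatter, all modest: a 4.3-fold higher number from compound 1 to compound 4 (0.64 log units; beyond the scatter), a 2.8-fold higher number from compound 3 to compound 4 (0.44 log units; beyond the scatter) and a 2.6-fold higher number from compound 2 to compound 4 (0.41 log units; beyond the scatter). The tolerance seen among the chains ending in 4-methylpiperazin-1-yl or piperidin-1-yl therefore does not fully extend to this group, although compound 4 still gives 390 nM. Nothing measured here accounts for these steps.

The swap exchanges the six-membered non-aromatic ring for the five-membered aromatic ring and also brings in the diol, so the contribution of each part remains unresolved. A triazole carrying a 4-methylpiperazin-1-yl chain, or a plain ethyl group in place of the 2,3-dihydroxypropyl, would separate the two.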